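A few compounds are considered here, and "the series" means these few. Any claim that something is new, unique, unknown or untested is made for them only; others in the source may bear on it.

Measured so far in a functional assay on the whole organism (blood, strain albino) with Mus musculus as the target, with stated times of 6 days and 3 h, at a dose of 1 mmol/kg by the oral route; a higher number here means more inhibition at the dose given (going by the name of the read-out), a lower number less inhibition:
compound 1 `CCN1C(=O)CCN(S(=O)(=O)c2ccc(-n3nc(C)cc3C)cc2)C1=S` — 4%
compound 2 `CCN1C(=O)CCN(S(=O)(=O)c2ccc(-n3nc(C(=O)O)cc3C)cc2)C1=S` — 1%

Going by the values given here, compound 1 gives the highest of the two numbers, though the only step, a number 3 percentage points lower from compound 1 to compound 2 (within the scatter), is within the scatter, so neither compound is set apart. Compound 3 `CCCCN1C(=O)CCN(S(=O)(=O)c2ccc(-n3nc(C)cc3C)cc2)C1=S` differs from compound 1 by ethyl in place of hydrogen on a saturated chain carbon, two bonds along the chain from an amide-type nitrogen in a ring. Among the compounds with values here, no measured step touches the ethyl on the core nitrogen; the one step known concerns a carboxy in place of methyl and is small. With both numbers near zero, compound 3 is expected to stay there: no change at the digits printed from compound 1 to compound 3 (within the scatter), giving an estimated 4% for compound 3, with a range from -8% to 16%.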

Compound 3, a percentage reported as inhibition, in the whole organism at one dose (the size of the read-out at that dose, not a potency): 1%
The estimate for compound 3 lay 3 percentage points above the measured number; the range from low to high includes it.
By their numbers in this assay, from the lowest: compounds 2, 3 and 1 (each within the scatter of the next).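

In this assay, the change at this position gives a number 3 percentage points lower from compound 1 to compound 3 (within the scatter), so going from ethyl to butyl on the core nitrogen opens no readable difference. Going by these compounds alone, this is the first step at this position, and it adds a second change that leaves the number within the scatter of compound 1. No available evidence bears on this result.

On these data alone, it remains open whether a chain longer than butyl, or an amine or a carboxylic acid at the end of this chain, would lift the number clear of the scatter.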